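This account rests on a few compounds, and the source may have more. Where it says the series, first, only, none or still open, it means among the compounds named here.

Working notes on the series.

In an assay for inhibition of 6-phosphofructo-2-kinase/fructose-2,6-bisphosphatase 3 (Homo sapiens), read by ADP-Glo, with a stated time of 2 h (on this read-out higher numbers stand for weaker inhibition and lower numbers for stronger inhibition), compound 1 `CN1CCCC(NS(=O)(=O)c2ccccc2Nc2cc(-c3ccc4ccn(C)c4c3)c3nccnc3c2)C1` gives 59 nM. Among the compounds with values here, compound 2 `CN1CCC(NS(=O)(=O)c2ccccc2Nc2cc(-c3ccc4ccn(C)c4c3)c3nccnc3c2)C1` gives 33 nM in this assay; the one single-point step measured so far, a 1.8-fold lower number from compound 1 to compound 2 (0.25 log units; within the scatter), stays within the scatter. Compound 3 `CN(C)C(=O)c1ccncc1Nc1cc(-c2ccc3ccn(C)c3c2)c2nccnc2c1` gives 499 nM in this assay, the highest of the three numbers, and its gaps to compound 1 and to compound 2 both lie beyond the scatter.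

Compound 4 `CC(=O)N1CC(NC(=O)c2ccncc2Nc2cc(-c3ccc4ccn(C)c4c3)c3nccnc3c2)C1` is not yet measured. It differs from compound 3 in one place: (1-acetylazetidin-3-yl)amino in place of dimethylamino on a carbonyl carbon. Within the data shown here, no measured step bears directly on this change; the only step available, a 1.8-fold lower number from compound 1 to compound 2 (0.25 log units; within the scatter), concerns a sulfonamide nitrogen in the other pair and was within the scatter, so it offers no guide on the carbonyl carbon of compound 3. Compound 4 is therefore expected to sit close to compound 3, with a step of a 1.1-fold lower number from compound 3 to compound 4 (0.04 log units; within the scatter) not beyond the scatter. The estimate for compound 4 in this assay is 450 nM, with a range from 150 nM to 1400 nM.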

Compound 4, half-maximal inhibitory concentration: 73 nM
For compound 4 the middle estimate is 6.2-fold (0.79 log units) above the measured one; the measured number lies below the stated range.
By their numbers in this assay, from the lowest: compounds 2, 1 and 4 (each within the scatter of the next, the first and the last beyond it); then compound 3.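

Within the data shown here, on a carbonyl carbon of the core of compound 3, the substituent matters in this assay: with (1-acetylazetidin-3-yl)amino in place of dimethylamino, the result is a 6.8-fold lower number from compound 3 to compound 4 (0.83 log units; beyond the scatter), the first single-place step to clear the scatter. The entering group brings an amide hydrogen, an acetyl group and a four-membered ring in one change, so this step alone cannot assign the shift to any one of these parts. Nothing at hand explains the step.

The compounds shown leave open whether the acetyl group is needed, which a free azetidin-3-ylamino amine would test, and whether a simple methylamino group would do as well. They also leave open how an open chain such as (2-acetamidoethyl)amino compares with the ring.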